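Adding a Hydroxymethyl Group on a Longer-Chain Analogue

The source may hold more compounds than are shown below. What is called first, only, known or untested is meant among the compounds shown, and "the series" means these compounds.

Three compounds have been measured in a functional assay on a cell-free system (plasma, Oryctolagus cuniculus) for inhibition of platelet-activating factor acetylhydrolase (Homo sapiens), tested at 100 nM; a higher number here means more inhibition at the concentration tested (going by the name of the read-out), a lower number less inhibition:
compound 1 `CCCCCCCCN(C)C(=O)Cn1cc(Cc2cnc(=O)n(C)c2)c(=O)nc1SCc1ccc(F)cc1` gives 19%;
compound 2 `CCCCCCCCN(C)C(=O)Cn1cc(Cc2cnc(=O)n(CCO)c2)c(=O)nc1SCc1ccc(F)cc1` gives 36%;
compound 3 `CCCCCCCCCCCCN(C)C(=O)Cn1cc(Cc2cnc(=O)n(CC(=O)NC)c2)c(=O)nc1SCc1ccc(F)cc1` gives 28%.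

Compound 2 differs from compound 1 by one change, (hydroxymethyl in place of hydrogen on a saturated chain carbon bound to an aromatic nitrogen), and this produced a number 17 percentage points higher from compound 1 to compound 2 (beyond the scatter). Compound 3 has a different core; the difference between the two cores is not broken down here. Compound 4 `CCCCCCCCCCCCN(C)C(=O)Cn1cc(Cc2cnc(=O)n(CC(=O)NCCO)c2)c(=O)nc1SCc1ccc(F)cc1` is not yet measured and carries the change (hydroxymethyl in place of hydrogen on a saturated chain carbon bound to an amide-type nitrogen). This is the same kind of change as before, but not the same: in compound 2 the new group sits on a saturated chain carbon bound to an aromatic nitrogen, in compound 4 on a saturated chain carbon bound to an amide-type nitrogen. Resting on the earlier step, compound 4 is expected to show a number 10 percentage points higher from compound 3 to compound 4 (within the scatter) in this assay, likely smaller than before. Compound 4 is estimated at 38%, between 22% and 55%.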

Compound 4, a percentage reported as inhibition, at one concentration (the size of the read-out at that concentration, not a potency): 37%
Compound 4: the middle estimate sits 1 percentage points above what was measured; measured number inside the range.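

In this assay, the hydroxymethyl group on the longer-chain analogue gives a number 9 percentage points higher from compound 3 to compound 4 (within the scatter), so this step alone cannot be told apart from the ordinary variation between repeat measurements. Set beside the earlier step, it shows no measurable difference between the two cores: the same change on two cores in this assay, a number 17 percentage points higher (beyond the scatter) from compound 1 to compound 2 and a number 9 percentage points higher (within the scatter) from compound 3 to compound 4, 8 percentage points apart, within the scatter of two such steps. This fits a change that carries over from one core to the other, but it does not show that the effect is equal on both, and a single pair on each core is thin support.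

The compounds shown leave open whether an amine or a carboxylic acid in place of the hydroxymethyl group would give a step of similar size. They also leave open how the change behaves on any further core.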